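Two methoxy groups in place of a nitro group

A few compounds are considered here, and "the series" means these few. Any claim that something is new, unique, unknown or untested is made for them only; others in the source may bear on it.

Among the compounds with values here, compound 3 `CSc1nc(NCCCCNc2ccnc3cc(Cl)ccc23)c(C#N)c(-c2ccc([N+](=O)[O-])cc2)n1` gives 760 nM in an ADME assay on CCRF-CEM cells (Homo sapiens) for inhibition, read by cell counting (on this read-out higher numbers stand for weaker inhibition and lower numbers for stronger inhibition), the lowest of the numbers measured so far. Compound 1 `CSc1nc(OCCCNc2ccnc3cc(Cl)ccc23)c(C#N)c(-c2ccccc2)n1` gives 3300 nM in this assay, a higher number that lies beyond the usual scatter from compound 3. Compound 2 `CSc1nc(-c2ccccc2)c(C#N)c(N2CCN(c3ccnc4cc(Cl)ccc34)CC2)n1` reaches only > 250000 nM in this assay, which is a limit of the measurement and not a number (the limit of > 250000 nM in this assay, at which 1 of the 3 values shown sits). Compound 4 `COc1ccc(-c2nc(SC)nc(NCCCCNc3ccnc4cc(Cl)ccc34)c2C#N)cc1OC` has not yet been measured; it differs from compound 3 by 3,4-dimethoxyphenyl in place of 4-nitrophenyl on an aromatic carbon. Within the data shown here, no measured pair shows this exchange, so the step of a 2.0-fold higher number from compound 3 to compound 4 (0.30 log units; within the scatter) is expected to be modest, with no clear direction beyond the scatter. Compound 4 is expected to give about 1500 nM in this assay, within a range from 400 nM to 6000 nM.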

Compound 4, half-maximal inhibitory concentration: 16000 nM
For compound 4 the middle estimate is 11-fold (1.03 log units) below the measured one; the whole stated range lies below it.
By their numbers in this assay, from the lowest: compound 3; then compound 1; then compound 4. At a limit, above all of these: compound 2.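

In this assay, 3,4-dimethoxyphenyl in place of 4-nitrophenyl on this aromatic carbon gives a 21-fold higher number from compound 3 to compound 4 (1.32 log units; beyond the scatter) with the rest of the molecule unchanged. Within the data shown here, this single exchange shows that the read-out depends strongly on which substituted phenyl sits here, which no earlier pair could show. Nothing measured here accounts for the size of this step.

The compounds shown leave open whether the step follows from losing the nitro group or from gaining the methoxy groups. A 4-methoxyphenyl or a 4-aminophenyl group at this place on the same molecule could help separate these.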